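Working notes: from nitro to fluoro on the benzamide

This account rests on a few compounds, and the source may have more. Where it says the series, first, only, none or still open, it means among the compounds named here.

Measured so far in a functional assay on MKN-45 cells (Homo sapiens) for cytotoxicity; on this read-out higher numbers stand for weaker inhibition and lower numbers for stronger inhibition
- compound 1 `COc1ccc(S(=O)(=O)N2CCc3cccc(NC(=O)C(C)(C)C)c32)cc1` gives 289 nM
- compound 2 `COc1ccc(S(=O)(=O)N2CCc3cccc(NS(=O)(=O)c4ccc(F)cc4)c32)cc1` gives 890 nM
- compound 3 `COc1ccc(S(=O)(=O)N2CCc3cccc(NC(=O)c4ccc([N+](=O)[O-])cc4)c32)cc1` gives 95 nM

Compound 3 holds the lowest number of the three, beyond the scatter from both others. Compound 4 `COc1ccc(S(=O)(=O)N2CCc3cccc(NC(=O)c4ccc(F)cc4)c32)cc1` has fluoro in place of nitro on an aromatic carbon, para to a large group: fluoro in place of nitro on an aromatic carbon. For the measured compounds named here, two measured steps bear on this. The first is a 3.0-fold lower number from compound 1 to compound 3 (0.48 log units; beyond the scatter), with 4-nitrophenyl in place of tert-butyl. The second is a 3.1-fold higher number from compound 1 to compound 2 (0.49 log units; beyond the scatter), with a (4-fluorophenyl)sulfonyl group entering. Both are modest, and neither compares nitro with fluoro directly. In this assay a modest step towards a higher number is therefore expected. The expected change is a 1.5-fold higher number from compound 3 to compound 4 (0.17 log units; within the scatter). Compound 4 is estimated at 140 nM, with an expected range of 45 nM to 420 nM.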

Compound 4, half-maximal inhibitory concentration: 45 nM
For compound 4 the middle estimate is 3.1-fold (0.49 log units) above the measured one; the measured number falls inside the stated range.
By their numbers in this assay, from the lowest: compound 4; then compound 3; then compound 1; then compound 2.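

In this assay, fluoro in place of nitro on an aromatic carbon, para to a large group, gives a 2.1-fold lower number from compound 3 to compound 4 (0.32 log units; beyond the scatter), so nitro is not needed at this position for a low number. With 4-fluorophenyl held constant, the carbonyl link compares favourably with the sulfonyl link, at a 20-fold lower number from compound 2 to compound 4 (1.30 log units; beyond the scatter), and with tert-butyl on the carbonyl carbon the change reads a 6.4-fold lower number from compound 1 to compound 4 (0.81 log units; beyond the scatter). Nothing at hand accounts for these steps.

Going by these compounds, how an amine or a nitrile at this position would compare with fluoro remains open. On these data alone, whether the gap between carbonyl and sulfonyl links holds with 4-nitrophenyl also remains open.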